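The source may hold more compounds than are shown below. What is called first, only, known or untested is meant among the compounds shown, and "the series" means these compounds.

Measured compounds:

Compound 1, `Nc1scc(-c2cccc(F)c2)c1C(=O)c1ccccc1`: 51%
Compound 2, `Nc1scc(-c2cccc(C(F)(F)F)c2)c1C(=O)c1ccc(Cl)cc1`: 64%
Compound 3, `Nc1scc(-c2ccccc2F)c1C(=O)c1ccc(Cl)cc1`: 70%

All three were tested in a functional assay on CHO cells for agonist activity at adenosine receptor A1 (Homo sapiens), read by fluorescence and ERK phosphorylation, with stated times of 30 min and 1.5 h, tested at 3 uM; on this read-out higher numbers stand for a stronger effect at the one concentration tested and lower numbers for a weaker effect. Compound 3 stands at the top of the three numbers, but the number of compound 2 sits within the usual scatter of it, so the two cannot be told apart; only compound 1 lies beyond the scatter below compound 3.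

Compound 4, `Nc1scc(-c2cccc(F)c2)c1C(=O)c1ccc(Cl)cc1`, has not yet been measured. It differs from compound 3 in one place: 3-fluorophenyl in place of 2-fluorophenyl on an aromatic carbon. For the measured compounds named here, since no step between two measured compounds that differ in only one place is available here, the size of this change has to be guessed from what the set shows. Compound 1 also carries a 3-fluorophenyl on the shared core and gives a lower number than compound 3, yet it differs in a second place as well, so it offers only a hint. The expectation is therefore a small downward step, or none beyond the scatter, for the step from compound 3 to compound 4, a number 8 percentage points lower from compound 3 to compound 4 (within the scatter). On that basis compound 4 is expected to give about 62% in this assay, with a likely range from 46% to 78%.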

Compound 4, a percentage reported as activity, at one concentration (the size of the read-out at that concentration, not a potency): 76%
Compound 4: the middle estimate sits 14 percentage points below what was measured, within the range that was stated.
By their numbers in this assay, from the lowest: compound 1; then compounds 2, 3 and 4 (each within the scatter of the next, the first and the last beyond it).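

In this assay, 3-fluorophenyl in place of 2-fluorophenyl on the shared core gives a number 6 percentage points higher from compound 3 to compound 4 (within the scatter), so this swap of the two fluorophenyl groups, on an aromatic carbon two ring bonds from the ring sulfur, makes no readable difference in this comparison. For the compounds shown here, compound 4 also supplies the first single-place comparisons in the set, and two of them clear the scatter: fluoro in place of trifluoromethyl gives a number 12 percentage points higher from compound 2 to compound 4 (beyond the scatter), and chloro in place of hydrogen on the other aromatic ring gives the larger a number 25 percentage points higher from compound 1 to compound 4 (beyond the scatter). Nothing among the data offered here explains why either number moves.

As far as these compounds go, each of these two steps is read on a single pair with 3-fluorophenyl or chloro already in place, so it remains open whether chloro in place of hydrogen gives a similar step alongside 2-fluorophenyl or trifluoromethyl. From the compounds shown here alone, it is also open how a methoxy group, an amine or a carboxylic acid would fare at either place, and, with a single concentration behind every number, how the compounds compare across a range of concentrations.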